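This account rests on a few compounds, and the source may have more. Where it says the series, first, only, none or still open, it means among the compounds named here.

Three compounds have been measured in an ADME assay on Vero cells (Chlorocebus sabaeus) for cytotoxicity, read by neutral red uptake, tested at 394 ug/mL; a higher number here means a weaker effect of the compound at the concentration tested, a lower number a stronger effect:

Compound 1 `O=C1CSC(c2c(Cl)cccc2Cl)N1CCN1CCCCC1` gives 32%.
Compound 2 `O=C1CSC(c2cccc(Cl)c2)N1CCN1CCCCC1` gives 45%.
Compound 3 `COc1ccccc1C1SCC(=O)N1CCN1CCCCC1` gives 67%.

Among these three numbers compound 2 stands second highest. Its nearest neighbour is compound 1, whose number lies lower by an amount beyond the scatter; the furthest is compound 3, whose number lies higher, again beyond the scatter.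

Compound 4 `O=C1CSC(c2cccc(F)c2)N1CCN1CCCCC1` has not yet been measured in this assay. It differs from compound 2 in one place: fluoro in place of chloro on an aromatic carbon.

Within the data shown here, no measured pair shows the effect of this change, so the expectation rests on compound 2 alone. The expected step from compound 2 to compound 4 in this assay is a number 7 percentage points higher from compound 2 to compound 4 (within the scatter), a small rise that may not exceed the scatter. Compound 4 is therefore estimated at 52%, within 36% to 70%.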

Compound 4, a percentage reported as activity, at one concentration (the size of the read-out at that concentration, not a potency): 60%
Beside the measured number, compound 4's estimate is 8 percentage points below it; measured number inside the range.
By their numbers in this assay, from the lowest: compound 1; then compound 2; then compounds 4 and 3 (each within the scatter of the next).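

In this assay, among these compounds, the change from 3-chlorophenyl to 3-fluorophenyl gives the only one-place step available (a number 15 percentage points higher from compound 2 to compound 4 (beyond the scatter)). It shows that, on this aromatic carbon meta to a large group, the read-out depends on which of these two halogens is present, and that exchanging one heavy atom is enough to move it beyond the scatter. No measurement shown explains this difference. The compounds shown leave open how a nitrile or an amine would read on this same carbon. They also leave open whether fluoro in place of chloro gives a similar step on another aromatic carbon.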